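One added methyl at the limit of the assay

The source may report more compounds than this note shows. Statements on the series, on what has been measured and on what is new or still open speak of the compounds shown alone.

In a functional assay on PA-1 cells (Homo sapiens) for antiproliferative activity, read by MTT assay, with a stated time of 48 h (a lower number here means a stronger inhibitor, a higher number a weaker inhibitor), compound 1 (`CCN1C(=O)C(O)(Cc2nnn[nH]2)c2ccccc21`) gives > 100000 nM as a limit of the assay, not a number. Compound 2 (`CN1C(=O)C(O)(Cc2nnn[nH]2)c2cc(Cl)ccc21`) gives > 100000 nM as a limit too. That places compound 2 at the limit of > 100000 nM in this assay, at which 2 of the 2 values shown sit, with no number to compare.

Compound 3 (`CCN1C(=O)C(O)(Cc2nnn[nH]2)c2cc(Cl)ccc21`) differs from compound 2 by methyl in place of hydrogen on a saturated chain carbon bound to an amide-type nitrogen in a ring on a saturated chain carbon bound to an amide-type nitrogen in a ring, a change that reads as methyl to ethyl. Compound 1 carries that ethyl and still gives > 100000 nM as a limit, so the expectation rests on it. In this assay the expected change a number no higher from compound 2 to compound 3 (the limit leaves the size open) is none beyond the scatter, and another limit is the likeliest report. The estimate for compound 3 is 100000 nM as a middle value, with an expected range from 40000 nM to 250000 nM in all.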

Compound 3, half-maximal inhibitory concentration: 49500 nM
The estimate for compound 3 lay 2.0-fold (0.31 log units) above the measured number, and the stated range covers the measured number.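

In this assay, compound 3 is the only compound shown that gives a number instead of a limit, so the methyl added on the saturated chain carbon bound to an amide-type nitrogen in a ring can now be given a floor: an at least 2.0-fold lower number from compound 2 to compound 3 (0.30 log units; that floor lies within the scatter). The chloro on the aromatic carbon can be read the same way, with an at least 2.0-fold lower number from compound 1 to compound 3 (0.30 log units; that floor lies within the scatter). Ethyl without chloro and chloro with only methyl both leave the compound at a limit, which is where the remaining compounds stand: the limit of > 100000 nM in this assay, at which 2 of the 3 values shown sit.

As far as these compounds go, the true size of both steps stays open, as neither limit says how far compound 1 or compound 2 lies from compound 3. Also open, from the compounds shown here alone, is whether a longer chain such as propyl in place of the ethyl, or bromo in place of the chloro, would give a lower number.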